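Series notes: cytotoxicity step from compound 2 to compound 4

The source may report more compounds than this note shows. Statements on the series, on what has been measured and on what is new or still open speak of the compounds shown alone.

Measured so far:
Compound 1 `Cc1ccc(Cn2cc(COc3ccc4c(=O)ccoc4c3)nn2)cc1`, in an ADME assay on L02 cells (Homo sapiens) for cytotoxicity, read by MTT assay, with a stated time of 48 h (on this read-out higher numbers stand for weaker inhibition and lower numbers for stronger inhibition), compound 1 gives > 300000 nM, a limit of the assay and not a number.
Compound 2 `N#Cc1ccc(Cn2cc(COc3ccc4c(=O)ccoc4c3)nn2)cc1`, in this assay compound 2 gives > 300000 nM, again only a limit.
Compound 3 `Cc1ccccc1Cn1cc(COc2ccc3c(=O)ccoc3c2)nn1`, in this assay compound 3 gives > 300000 nM, again only a limit.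

All three values sit at the limit of > 300000 nM in this assay, at which 3 of the 3 values shown sit, so the three steps between them, a step that the two limits leave unreadable from compound 1 to compound 2, a step that the two limits leave unreadable from compound 1 to compound 3 and a step that the two limits leave unreadable from compound 2 to compound 3, cannot be read in size or direction. Compound 2 thus stands only at a limit, and the two other values shown are limits as well.

Compound 4 `CC(C)(C)c1ccc(Cn2cc(COc3ccc4c(=O)ccoc4c3)nn2)cc1` is not yet measured. It differs from compound 2 in one place: tert-butyl in place of cyano on an aromatic carbon. Within the data shown here, the steps that bear on this change, a step that the two limits leave unreadable from compound 1 to compound 2 and a step that the two limits leave unreadable from compound 2 to compound 3, alter the same position yet remain unreadable, so no step beyond the scatter can be expected in this assay in either direction, and a further limit is the likelier outcome. Compound 4 is therefore expected to give 300000 nM, within 150000 nM to 600000 nM. The step this estimate implies is a number no higher from compound 2 to compound 4 (the limit leaves the size open).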

Compound 4, half-maximal inhibitory concentration: > 300000 nM
Compound 4: a limit, no number; the forecaster's own chance of this, stated with the estimate: 85%; the middle value lies on the limit itself.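

In this assay compound 4 gives > 300000 nM, a limit and not a number, so its steps from compound 1 and compound 2 cannot be read: the limit of > 300000 nM in this assay, at which 4 of the 4 values shown sit.

The compounds shown leave open how methyl, cyano and tert-butyl compare in this assay, since none of compounds 1, 2 and 4 gives a number.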